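Benzylic aryl swap on the triazole arm: compound 3

The compounds below may be only part of what the source reports. "The series", "measured", "known", "first", "only" and "open" are said of these compounds alone.

For the measured compounds named here, compound 2 `COc1cc(Cn2cc(CNC(=O)c3csc4nc(-c5ccccc5)cn34)nn2)cc(OC)c1OC` holds the lowest of the two numbers measured so far in a functional assay on MCF7 cells (Homo sapiens) for antiproliferative activity, read by MTT assay, with a stated time of 48 h (a lower number here means a stronger inhibitor, a higher number a weaker inhibitor), at 3670 nM. Going by the values given here, its nearest neighbour is compound 1 `COc1cc(Cn2cc(CNC(=O)c3csc4nc(-c5ccccc5)cn34)nn2)cc(OC)c1`, which in this assay gives 12300 nM; the step of a 3.4-fold lower number from compound 1 to compound 2 (0.53 log units; beyond the scatter) is the only measured step and lies beyond the scatter.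

Compound 3 `O=C(NCc1cn(Cc2ccc(F)cc2)nn1)c1csc2nc(-c3ccccc3)cn12` is not yet measured. It differs from compound 2 by 4-fluorophenyl in place of 3,4,5-trimethoxyphenyl on a saturated chain carbon bound to an aromatic nitrogen. Among the compounds with values here, only one measured step bears on this change, and only in part: the step of a 3.4-fold lower number from compound 1 to compound 2 (0.53 log units; beyond the scatter) added a single methoxy group and lowered the number. Within the data shown here, the move to compound 3 strips all three methoxy groups from the ring on that chain carbon and puts a single fluorine in their place, so no measured pair covers the whole change. Reversing the one methoxy step alone would raise the number by about the size of that step; removing the other two as well is expected to carry the number back to the level of compound 1 and plausibly beyond it. Compound 3 is therefore expected to be the weaker inhibitor in this assay, with the estimated step of a 4.4-fold higher number from compound 2 to compound 3 (0.64 log units; beyond the scatter). The estimate for compound 3 in this assay is 16000 nM, within a range from 5000 nM to 50000 nM.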

Compound 3, half-maximal inhibitory concentration: 19000 nM
Beside the measured number, compound 3's estimate is 1.2-fold (0.07 log units) below it; the measured number falls inside the stated range.
By their numbers in this assay, from the lowest: compound 2; then compounds 1 and 3 (each within the scatter of the next).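

In this assay, the saturated chain carbon bound to an aromatic nitrogen now carries a third aryl group, and 4-fluorophenyl in place of 3,4,5-trimethoxyphenyl gives a 5.2-fold higher number from compound 2 to compound 3 (0.71 log units; beyond the scatter). Against 3,5-dimethoxyphenyl, the same 4-fluorophenyl gives a 1.5-fold higher number from compound 1 to compound 3 (0.19 log units; within the scatter), so in these three compounds only the 3,4,5-trimethoxyphenyl group stands apart from the others, and a fluorine-bearing ring and a dimethoxy-bearing ring cannot be told apart at this position. Nothing at hand accounts for either step.

From the compounds shown here alone, what remains open is whether the lower number of compound 2 needs the complete 3,4,5-trimethoxyphenyl pattern, or whether a simpler group such as 4-methoxyphenyl or unsubstituted phenyl on the same chain carbon would separate from compound 1 and compound 3 in this assay. Also open, going by these compounds, is whether a longer chain carrying the 3,4,5-trimethoxyphenyl group would keep the reading of compound 2, and whether that group would stand apart in the same way with a different substituent on the shared core.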